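A few compounds are considered here, and "the series" means these few. Any claim that something is new, unique, unknown or untested is made for them only; others in the source may bear on it.

Measured compounds and their values:

compound 1, `CCCCCCCCCCCCCCC(NC(=O)OC(C)(C)C)C(=O)O` — in an ADME assay on cells (Splenocyte, Mus musculus, strain BALB/c) for cytotoxicity, read by MTT assay, tested at 10 ug/mL (a lower number here means a weaker effect, a higher number a stronger effect of the compound at the concentration tested), compound 1 gives 5.1%
compound 2, `CCCCCCCCCCCCCCC(COCc1ccccc1)NCC` — in this assay compound 2 gives 11.9%

Compound 2 stands at the top of the two numbers seen so far in this assay, but its nearest neighbour, compound 1, lies within the scatter of it, so the two are not separated. Going by the values given here, no step between measured compounds that differ in one place is available, and nothing measured links either of them to compound 3.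

Compound 3, `CCCCCCCCCCCCCCC(COCc1ccccc1)N(CC)CC`, is still to be measured in this assay. It differs from compound 2 as follows:

ethyl in place of hydrogen on an amine nitrogen

With no measured step of this kind in the series, the change from ethylamino to diethylamino gives no ground for expecting a shift beyond the scatter in this assay, in either direction. The step is estimated as a number 2.1 percentage points higher from compound 2 to compound 3 (within the scatter) for compound 3, essentially flat. Compound 3 is expected to give about 14%, with a range from 4% to 27%.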

Compound 3, a percentage reported as activity, at one concentration (the size of the read-out at that concentration, not a potency): 15.6%
Compound 3: middle estimate off by 1.6 percentage points, on the low side, and the stated range covers the measured number.
By their numbers in this assay, from the lowest: compounds 1, 2 and 3 (each within the scatter of the next, the first and the last beyond it).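

Going by these compounds alone, on the amine nitrogen, ethyl in place of hydrogen gives the first measured step: in this assay, the change reads a number 3.7 percentage points higher from compound 2 to compound 3 (within the scatter). The change from ethylamino to diethylamino therefore has no effect separable from the scatter in this single pair, so this site accepts a second ethyl group without a resolved shift in the read-out at the concentration tested. No measurement available here bears on why the read-out behaves this way.

Still open, going by these compounds, is whether a longer chain such as butyl, a ring amine such as piperidine, or the unsubstituted primary amine on this nitrogen would give a step beyond the scatter. Also open, on these data alone, is whether a free hydroxyl in place of the benzyl ether would change the read-out.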